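The compounds below may be only part of what the source reports. "The series", "measured", "known", "first", "only" and "open" are said of these compounds alone.

Measured so far:
compound 1 `COc1nc(-c2ccccc2)cc(-c2ccc(F)cc2)c1C#N`: 25 nM
compound 2 `COc1ccc(-c2cc(-c3ccc(F)cc3)c(C#N)c(OC)n2)cc1`: 1360 nM
compound 3 `COc1cccc(-c2cc(-c3ccc(F)cc3)c(C#N)c(OC)n2)c1`: 108 nM

In an assay on isolated protein for inhibition of sulfide:quinone oxidoreductase, mitochondrial (Homo sapiens) (a lower number here means a stronger inhibitor, a higher number a weaker inhibitor), compound 1 gives the lowest of the three numbers. Its nearest neighbour is compound 3, with a 4.3-fold higher number from compound 1 to compound 3 (0.64 log units; beyond the scatter); its furthest is compound 2, with a 54-fold higher number from compound 1 to compound 2 (1.74 log units; beyond the scatter); between those two, a 13-fold lower number from compound 2 to compound 3 (1.10 log units; beyond the scatter). Compound 4 `COc1nc(-c2ccccc2)cc(-c2ccc(Cl)cc2Cl)c1C#N` is not yet measured. It differs from compound 1 by 2,4-dichlorophenyl in place of 4-fluorophenyl on an aromatic carbon. As far as these compounds go, every measured step instead alters the phenyl group, so none bears directly on this change; the change at the 4-fluorophenyl position is untested. For compound 4 the estimate in this assay is therefore a modest step, a 2.4-fold higher number from compound 1 to compound 4 (0.38 log units; beyond the scatter), with a wide range: expected 60 nM, from 10 nM to 400 nM.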

Compound 4, half-maximal inhibitory concentration: > 100000 nM
Compound 4: no number, only a limit; the forecaster's own chance of this, stated with the estimate: 3%; at least 1600-fold (3.22 log units) between middle value and limit.
By their numbers in this assay, from the lowest: compound 1; then compound 3; then compound 2. At a limit, above all of these: compound 4.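

Compound 4 carries a limit, not a number, in this assay: the limit of > 100000 nM in this assay, at which 1 of the 4 values shown sits. The position held by the 4-fluorophenyl group, opposite the ring nitrogen, proves far from tolerant: 2,4-dichlorophenyl there gives an at least 4000-fold higher number from compound 1 to compound 4 (3.60 log units; beyond the scatter). This step exceeds the largest one seen on the phenyl group, a 54-fold higher number from compound 1 to compound 2 (1.74 log units; beyond the scatter), so the series can lose its activity through this single change.

As far as these compounds go, whether the loss follows one chlorine or both stays open. Also open, from the compounds shown here alone, is how an unsubstituted phenyl or a pyridyl group would read at this position.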